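The source may hold more compounds than are shown below. What is called first, only, known or untested is meant among the compounds shown, and "the series" means these compounds.

Among the measured compounds shown here, compound 2 `C=CC(=O)Nc1cccc(NC(=O)CSc2nc(Nc3cccc(F)c3)c3ccccc3n2)c1` is one of two compounds measured in a functional assay on MDA-MB-231 cells (Homo sapiens) for inhibition, read by MTT assay, with a stated time of 72 h (on this read-out lower numbers stand for stronger inhibition and higher numbers for weaker inhibition), where compound 2 gives 8160 nM. For the measured compounds named here, compound 1 `C=CC(=O)Nc1cccc(NC(=O)CSc2nc(Nc3ccccc3Cl)c3ccccc3n2)c1` gives 12700 nM in this assay, and the single measured step, a 1.6-fold lower number from compound 1 to compound 2 (0.19 log units; within the scatter), lies within the scatter, so compound 2 and compound 1 cannot be told apart on these numbers. Compound 3 `C=CC(=O)Nc1cccc(NC(=O)CSc2nc(Nc3cccc(Br)c3)c3ccccc3n2)c1` differs from compound 2 by bromo in place of fluoro on an aromatic carbon. No measured step exchanges one halogen for another at the same place, so nothing shown points to a shift beyond the scatter. Compound 3 is therefore expected to give 7000 nM, with a range from 3500 nM to 16000 nM. The expected step is a 1.2-fold lower number from compound 2 to compound 3 (0.07 log units; within the scatter), within the scatter.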

Compound 3, half-maximal inhibitory concentration: 19400 nM
Beside the measured number, compound 3's estimate is 2.8-fold (0.44 log units) below it; the measured number lies above the stated range.
By their numbers in this assay, from the lowest: compounds 2, 1 and 3 (each within the scatter of the next, the first and the last beyond it).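

In this assay, among the compounds shown here, the halogen on this aromatic carbon, meta to a large group, does register: bromo in place of fluoro gives a 2.4-fold higher number from compound 2 to compound 3 (0.38 log units; beyond the scatter), a modest change but the only step here beyond the scatter. By contrast, 3-bromophenyl in place of 2-chlorophenyl gives a 1.5-fold higher number from compound 1 to compound 3 (0.18 log units; within the scatter), which stays within the scatter. Nothing available here accounts for the step from fluoro to bromo.

As far as these compounds go, whether chloro at this place would stand with fluoro or with bromo remains open. So does the outcome with a non-halogen group there, such as an amine or a methoxy group.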